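Ester to Amide in a Series Without a Measured Number

The compounds below may be only part of what the source reports. "The series", "measured", "known", "first", "only" and "open" are said of these compounds alone.

Measured so far:
- compound 1, `COC(=O)[C@H]1C[C@@H](c2coc3ccccc3c2=O)N(c2ccccc2)O1`: > 60000 nM (a limit)
- compound 2, `COC(=O)[C@H]1C[C@@H](c2coc3ccc(Cl)cc3c2=O)N(c2ccccc2)O1`: > 60000 nM (a limit)
- compound 3, `COC(=O)[C@@]1(C)C[C@@H](c2coc3ccc(C)cc3c2=O)N(c2ccccc2)O1`: > 60000 nM (a limit)

In a functional assay on PC-3 cells (Homo sapiens) for inhibition, read by sulforhodamine B assay, with a stated time of 48 h (a lower number here means a stronger inhibitor, a higher number a weaker inhibitor), compound 1 gives > 60000 nM, which is a limit of the assay and not a number. Compound 2 gives > 60000 nM, likewise a limit. Compound 3 gives > 60000 nM, also a limit. All three values sit at the limit of > 60000 nM in this assay, at which 3 of the 3 values shown sit, so compound 1 cannot be placed above or below the other two, and nothing in these numbers separates the compounds from one another. Among the measured compounds shown here, the only single-place step among them, a step that the two limits leave unreadable from compound 1 to compound 2, is for this reason unreadable.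

Compound 4, `NC(=O)[C@H]1C[C@@H](c2coc3ccccc3c2=O)N(c2ccccc2)O1`, differs from compound 1 in one place: amino in place of methoxy on a carbonyl carbon. For the measured compounds named here, no measured step concerns this position, and the one step that exists, a step that the two limits leave unreadable from compound 1 to compound 2, was not readable, so it offers no size to carry over. The expected step that the limit leaves unreadable from compound 1 to compound 4 is therefore none beyond the scatter, with another limit the likeliest outcome. Compound 4 is estimated at 80000 nM, between 20000 nM and 300000 nM.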

Compound 4, half-maximal inhibitory concentration: > 60000 nM
Compound 4: a limit, no number (the forecaster's own chance of this, stated with the estimate: 85%); the middle value lies beyond the limit too.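

No step can be read from compound 1 to compound 4, because both values are limits and not numbers: the limit of > 60000 nM in this assay, at which 4 of the 4 values shown sit. The compounds shown leave open whether any change to the shared core would give a readable number in this assay.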